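Series notes: 8-hydroxyquinoline-2-carboxamides, lipophilicity before compound 3

A few compounds are considered here, and "the series" means these few. Any claim that something is new, unique, unknown or untested is made for them only; others in the source may bear on it.

Measured so far:
compound 1 `O=C(Nc1ccccc1F)c1ccc2cccc(O)c2n1` gives 2.5
compound 2 `O=C(Nc1cccc(Cl)c1)c1ccc2cccc(O)c2n1` gives 2.5

In a physicochemical assay for lipophilicity, read by HPLC (on this read-out lower numbers stand for lower lipophilicity and higher numbers for higher lipophilicity), compound 2 stands level with compound 1 at the digits shown; the step of no change at the digits printed from compound 1 to compound 2 (within the scatter) lies within the scatter, so between these two the read-out does not move.

Compound 3 `O=C(Nc1cccc([N+](=O)[O-])c1)c1ccc2cccc(O)c2n1` is the next member. It differs from compound 2 by nitro in place of chloro on an aromatic carbon of a six-membered aromatic ring of carbon only, meta to a large group. For the measured compounds named here, no measured step bears directly on this change: the only step in hand swaps one halogen-bearing phenyl for another and was flat. The change itself, which removes one heavy atom and brings in three together with two hydrogen-bond acceptors, is of a different kind, and without a matching measured step the expectation can only be that this assay moves downward by a modest amount. For compound 3 a value of 2 is expected, with a range from 1.5 to 2.5. The expected step of a number 0.50 log units lower from compound 2 to compound 3 (beyond the scatter) is therefore estimated to be larger than the scatter.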

Compound 3, partition coefficient: 2.5
For compound 3 the middle estimate is 0.50 log units below the measured one; the range from low to high includes it.
By their numbers in this assay, from the lowest: compounds 1, 2 and 3 (each within the scatter of the next).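

At this place, on an aromatic carbon of a six-membered aromatic ring of carbon only and meta to a large group, this assay shows no change at the digits printed from compound 2 to compound 3 (within the scatter) for nitro in place of chloro. The earlier step, no change at the digits printed from compound 1 to compound 2 (within the scatter), only exchanged one halogen-bearing phenyl for another, whereas this one replaces the halogen with a group that brings in hydrogen-bond acceptors, and the read-out still stays flat. No evidence in hand accounts for this flat read-out.

From the compounds shown here alone, whether the read-out also holds with an amine or a carboxylic acid at this place remains open, as it does for a longer chain such as butoxy. Compounds 1, 2 and 3 share one core, so they also leave open what a change on the core itself would do.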